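Half-life outlook for the aryloxy analogue, compound 4

The source may hold more compounds than are shown below. What is called first, only, known or untested is meant among the compounds shown, and "the series" means these compounds.

Three compounds of the shared core have numbers in an ADME assay for pharmacokinetics, tested at 1 uM, in the presence of a further agent that is not named here; on this read-out higher numbers stand for a longer-lived compound and lower numbers for a shorter-lived compound. Compound 1 `COCCOc1cc2ncnc(NC3=CC(=O)C(SC)=CC3=O)c2cc1OC` gives 2 h; compound 2 `COCCOc1cc2ncnc(NC3=CC(=O)C(N(C)c4ccccc4)=CC3=O)c2cc1OC` gives 341 h; compound 3 `COCCOc1cc2ncnc(NC3=CC(=O)C(OC)=CC3=O)c2cc1OC` gives 68 h. Compound 3 stands second highest of the three, separated from compound 2 by a 5.0-fold lower number from compound 2 to compound 3 (0.70 log units; beyond the scatter) and from compound 1 by a 34-fold higher number from compound 1 to compound 3 (1.53 log units; beyond the scatter). Compound 4 `COCCOc1cc2ncnc(NC3=CC(=O)C(Oc4ccc(-n5ccnc5)cc4)=CC3=O)c2cc1OC` is not yet measured; it differs from compound 3 by 4-(1H-imidazol-1-yl)phenyl in place of methyl on an oxygen on an unsaturated carbon. The step that bears most closely on this change is a 5.0-fold lower number from compound 2 to compound 3 (0.70 log units; beyond the scatter), where the group carrying a phenyl on the heteroatom at this place gave the higher number than methyl did; a 170-fold higher number from compound 1 to compound 2 (2.23 log units; beyond the scatter) points the same way but also swaps the heteroatom. Going by the values given here, no measured step covers the imidazole part, and the attachment through oxygen rather than nitrogen is untested with an aryl group. A modest rise in this assay is therefore expected, a 1.8-fold higher number from compound 3 to compound 4 (0.25 log units; within the scatter), with wide uncertainty on either side. Compound 4 is estimated at 120 h, between 30 h and 500 h.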

Compound 4, half-life: < 0.02 h
Compound 4: only a limit was reported; the forecaster's own chance of this, stated with the estimate: 5%; middle value at least 6000-fold (3.77 log units) from the limit.
By their numbers in this assay, from the lowest: compound 1; then compound 3; then compound 2. At a limit, below all of these: compound 4.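

At this place, on an oxygen on an unsaturated carbon, a large aryl group does not extend the trend seen with methyl(phenyl)amino: methoxy to 4-(1H-imidazol-1-yl)phenoxy gives the widest drop seen from a methoxy compound (an at least 3400-fold lower number from compound 3 to compound 4 (3.53 log units; beyond the scatter)). The aryloxy compound also falls far short of the nitrogen-linked aryl compound (an at least 17000-fold lower number from compound 2 to compound 4 (4.23 log units; beyond the scatter)) and of the shortest-lived earlier compound, the methylsulfanyl one (an at least 100-fold lower number from compound 1 to compound 4 (2.00 log units; beyond the scatter)), so a phenyl on the heteroatom does not by itself carry a long half-life in this series. In this assay compound 4 stands at < 0.02 h, which is a limit of the assay and not a number: the limit of < 0.02 h in this assay, at which 1 of the 4 values shown sits.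

Still open, on these data alone, is whether the fall belongs to the phenoxy link or to the imidazole ring. An unsubstituted phenoxy group, or a phenylamino group carrying the same imidazole, would separate the two.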